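Cytotoxicity of a Piperidine Variant Within an Oxazolidinone Series

The source may hold more compounds than are shown below. What is called first, only, known or untested is meant among the compounds shown, and "the series" means these compounds.

Compound 3 `COC(=O)CC1CCN(C[C@H]2CN(c3ccc(-n4cc(-c5ccccn5)cn4)c(F)c3)C(=O)O2)CC1` gives the highest of the two numbers in an ADME assay on HEK293-A cells (Homo sapiens) for cytotoxicity, read by MTT assay, with a stated time of 48 h (a lower number here means a stronger inhibitor, a higher number a weaker inhibitor), at 224 ug/mL. Compound 2 `CN1CCN(C[C@H]2CN(c3ccc(-n4cc(-c5ccccn5)cn4)c(F)c3)C(=O)O2)CC1` gives 70 ug/mL in this assay, and the step of a 3.2-fold higher number from compound 2 to compound 3 (0.51 log units; beyond the scatter) lies beyond the scatter. Compound 1 `CN(CCC#N)C[C@H]1CN(c2ccc(-n3cc(-c4ccccn4)cn3)c(F)c2)C(=O)O1` gives only a limit of the assay, > 400 ug/mL (the limit of > 400 ug/mL in this assay, at which 1 of the 3 values shown sits). Compound 4 `O=C1O[C@@H](CN2CCC(c3ccc(F)cc3)CC2)CN1c1ccc(-n2cc(-c3ccccn3)cn2)c(F)c1` differs from compound 3 in one place: 4-fluorophenyl in place of (methoxycarbonyl)methyl on a saturated ring carbon. Every measured step, an at least 5.7-fold lower number from compound 1 to compound 2 (0.75 log units; beyond the scatter) and an at least 1.7-fold lower number from compound 1 to compound 3 (0.25 log units; that floor lies within the scatter) and a 3.2-fold higher number from compound 2 to compound 3 (0.51 log units; beyond the scatter), exchanged the whole amine rather than a group on the piperidine ring, so none bears directly on this change; those steps were at most modest. Compound 4 is therefore expected to give a number close to compound 3, estimated at 150 ug/mL (from 50 ug/mL to 400 ug/mL), a step of a 1.5-fold lower number from compound 3 to compound 4 (0.17 log units; within the scatter) that is expected to stay near the scatter.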

Compound 4, half-maximal inhibitory concentration: > 400 ug/mL
Compound 4: no number, only a limit; the forecaster's own chance of this, stated with the estimate: 15%; middle value at least 2.6-fold (0.42 log units) away from the limit.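

Compound 4 gives no number in this assay, only a limit of the assay, and it is the second compound shown to do so: the limit of > 400 ug/mL in this assay, at which 2 of the 4 values shown sit. The step, an at least 1.7-fold higher number from compound 3 to compound 4 (0.25 log units; that floor lies within the scatter), gives only a floor, so its true size cannot be read. It is still the first change shown on the piperidine ring itself, and placing 4-fluorophenyl on this saturated ring carbon did not lower the number.

Going by these compounds, what a carboxylic acid or a primary amine on this ring carbon would give remains open. So does whether a plain phenyl would also reach the limit.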